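Notes on compound 4: chloro in place of fluoro

A few compounds are considered here, and "the series" means these few. Any claim that something is new, unique, unknown or untested is made for them only; others in the source may bear on it.

Three compounds of the shared core have been run in a functional assay on CHO cells with adenosine receptor A1 (Homo sapiens) as the target, read by cAMP accumulation and immunoassay, with a stated time of 6 min, tested at 0.1 uM; a higher number here means a weaker effect of the compound at the concentration tested, a lower number a stronger effect. Compound 1 `Nc1scc(CN2CCN(c3ccc(Cl)cc3Cl)CC2)c1C(=O)c1ccc(Cl)cc1` gives -11%, compound 2 `Nc1scc(CN2CCN(c3ccc(Cl)c(C(F)(F)F)c3)CC2)c1C(=O)c1ccc(Cl)cc1` gives -12%, and compound 3 `Nc1scc(CN2CCN(c3ccccc3F)CC2)c1C(=O)c1ccc(Cl)cc1` gives -1%. On paper the number of compound 3 is the highest of the three, but the step of a number 10 percentage points higher from compound 1 to compound 3 (within the scatter) lies within the scatter; only a number 11 percentage points higher from compound 2 to compound 3 (beyond the scatter) lies beyond it. Compound 4 `Nc1scc(CN2CCN(c3ccccc3Cl)CC2)c1C(=O)c1ccc(Cl)cc1` differs from compound 3 by chloro in place of fluoro on an aromatic carbon; the group sits on an aromatic carbon of a six-membered aromatic ring of carbon only, ortho to a large group, so the whole reads 2-fluorophenyl to 2-chlorophenyl. Among the measured compounds shown here, no measured step exchanges a single halogen at one place; the nearest is a number 10 percentage points higher from compound 1 to compound 3 (within the scatter), where 2,4-dichlorophenyl gave way to 2-fluorophenyl inside the scatter, and a number 1 percentage points lower from compound 1 to compound 2 (within the scatter) also stayed inside it. A step beyond the scatter in this assay is therefore not expected for compound 4. The estimate for compound 4 is -5%, ranging from -20% to 10%. The step this estimate means, a number 4 percentage points lower from compound 3 to compound 4 (within the scatter), is expected to stay within the scatter.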

Compound 4, a percentage reported as activity, at one concentration (the size of the read-out at that concentration, not a potency): 2%
Estimate against measurement, compound 4: 7 percentage points below, and the stated range covers the measured number.
By their numbers in this assay, from the lowest: compounds 2, 1, 3 and 4 (each within the scatter of the next, the first and the last beyond it).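

Chloro in place of fluoro on an aromatic carbon, ortho to a large group, is the first exchange of one halogen at a single place in this assay, and it gives a number 3 percentage points higher from compound 3 to compound 4 (within the scatter), so the two halogens are not told apart here. The 2-chlorophenyl also gives steps beyond the scatter against both more substituted aryl groups: hydrogen in place of chloro on an aromatic carbon gives a number 13 percentage points higher from compound 1 to compound 4 (beyond the scatter), and 2-chlorophenyl in place of 4-chloro-3-(trifluoromethyl)phenyl gives a number 14 percentage points higher from compound 2 to compound 4 (beyond the scatter). No data on hand offer an explanation for these steps.

From the compounds shown here alone, whether a methyl or methoxy group at this place would stay within the scatter of these halogens remains open. A read-out at one concentration also leaves open how far the potencies of these compounds differ.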